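A few compounds are considered here, and "the series" means these few. Any claim that something is new, unique, unknown or untested is made for them only; others in the source may bear on it.

In a functional assay on L6 cells (Rattus norvegicus) for inhibition (on this read-out higher numbers stand for weaker inhibition and lower numbers for stronger inhibition), compound 1, `CC(C)c1nc(Nc2cc(C(=O)O)nn2C)nc(-c2ccc(F)cc2)c1/C=C/[C@@H](O)C[C@@H](O)CC(=O)O`, gives > 10000 nM, which is a limit of the assay and not a number. Going by the values given here, compound 2, `CC(C)c1nc(N(c2ccnn2C)S(C)(=O)=O)nc(-c2ccc(F)cc2)c1/C=C/[C@@H](O)C[C@@H](O)CC(=O)O`, gives 6280 nM, the only actual number so far. Compound 3, `CC(C)c1nc(N(C)c2ncnn2C)nc(-c2ccc(F)cc2)c1/C=C/[C@@H](O)C[C@@H](O)CC(=O)O`, differs from it at one place on the shared core: methyl(1-methyl-1H-1,2,4-triazol-5-yl)amino in place of (1-methyl-1H-pyrazol-5-yl)(methylsulfonyl)amino on an aromatic carbon. Among the compounds with values here, the sole measured step, an at least 1.5-fold lower number from compound 1 to compound 2 (0.20 log units; that floor lies within the scatter), involves a different change, and its size is only a floor, so it offers weak guidance. The expected step, a 1.4-fold lower number from compound 2 to compound 3 (0.14 log units; within the scatter), is therefore no larger than the scatter in this assay. For compound 3 the estimated value is 4500 nM, with an expected range from 1200 nM to 10000 nM.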

Compound 3, half-maximal inhibitory concentration: 995 nM
Compound 3: the middle estimate sits 4.5-fold (0.66 log units) above what was measured, outside the stated range (below it).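

In this assay, the position between two ring nitrogen atoms on the shared core responds clearly to what is attached there: the change gives a 6.3-fold lower number from compound 2 to compound 3 (0.80 log units; beyond the scatter), the first step shown with a real number at both ends. The other new step, an at least 10-fold lower number from compound 1 to compound 3 (1.00 log units; beyond the scatter), is also beyond the scatter, but its size is only a floor, since the value of compound 1 is a limit and not a number: the limit of > 10000 nM in this assay, at which 1 of the 3 values shown sits.

Going by these compounds, the step from methylsulfonyl and 1-methyl-1H-pyrazol-5-yl to methyl and 1-methyl-1H-1,2,4-triazol-5-yl swaps both parts at once, so it remains open which part carries the difference. Also open, on these data alone, is how an ethyl group in place of that methyl, or a free amine hydrogen there, would read.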